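Swapping one amide ring for a chloropyridine

The source may hold more compounds than are shown below. What is called first, only, known or untested is meant among the compounds shown, and "the series" means these compounds.

Of the compounds shown here, two built on a shared core have been measured in a functional assay on MDA-MB-468 cells (Homo sapiens) for antiproliferative activity, read by MTT assay, with a stated time of 72 h; a lower number here means a stronger inhibitor, a higher number a weaker inhibitor. Compound 1 `O=C(Nc1ccc(Cl)c(-c2nnc3c(Cl)cccn23)c1)c1cccc(Cl)c1` carries a 3-chlorophenyl on the carbonyl carbon of its amide, and in this assay compound 1 gives 54800 nM. Compound 2 `O=C(Nc1ccc(Cl)c(-c2nnc3c(Cl)cccn23)c1)c1c(F)cccc1Cl` carries a 2-chloro-6-fluorophenyl at that carbonyl carbon, and in this assay compound 2 gives 57600 nM. The step of a 1.1-fold higher number from compound 1 to compound 2 (0.02 log units; within the scatter) is too small to count as a real difference, so compound 2 holds the higher of the two numbers without being separable from compound 1; both are weak inhibitors.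

Compound 3 `O=C(Nc1ccc(Cl)c(-c2nnc3c(Cl)cccn23)c1)c1cccnc1Cl` has not been measured. It differs from compound 2 by 2-chloropyridin-3-yl in place of 2-chloro-6-fluorophenyl on a carbonyl carbon. Going by the values given here, the only measured step that bears on this place is a 1.1-fold higher number from compound 1 to compound 2 (0.02 log units; within the scatter), where exchanging one ring for another on the carbonyl carbon left the number essentially unchanged. No step beyond the scatter is therefore expected here, in either direction. For compound 3 the expected value in this assay is 50000 nM, with a range from 20000 nM to 130000 nM. That expectation means a step of a 1.2-fold lower number from compound 2 to compound 3 (0.06 log units; within the scatter).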

Compound 3, half-maximal inhibitory concentration: > 100000 nM
Compound 3 gave a limit, no number (the forecaster's own chance of this, stated with the estimate: 20%); middle value at least 2.0-fold (0.30 log units) away from the limit.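

Going by these compounds alone, compound 3 is the first of the three to carry a ring with a hetero atom on the carbonyl carbon, and in this assay compound 3 gives > 100000 nM, which is a limit of the assay and not a number. Measured against the two rings of carbon only, the new ring shows an at least 1.7-fold higher number from compound 2 to compound 3 (0.23 log units; that floor lies within the scatter) and an at least 1.8-fold higher number from compound 1 to compound 3 (0.26 log units; that floor lies within the scatter), so 2-chloropyridin-3-yl, with its hydrogen-bond acceptor, gives no sign of a stronger inhibitor at this place. Unlike the step from compound 1 to compound 2, these two steps have a floor but no upper end, so a real loss here is possible but not shown, and the only evidence on it is where the value sits: the limit of > 100000 nM in this assay, at which 1 of the 3 values shown sits.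

On these data alone, all three rings on the carbonyl carbon carry a chlorine, so it stays open whether a ring without one would read any differently. As far as these compounds go, it also stays open whether an amine or a carboxylic acid on the ring, or a longer chain in place of the ring, would move the number at this place in either direction.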